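This account rests on a few compounds, and the source may have more. Where it says the series, first, only, none or still open, it means among the compounds named here.

Compound 1 `CCn1cnc2ncnc(N)c21` was examined in a functional assay on CHO cells for antagonist activity at adenosine receptor A2b (Homo sapiens); on this read-out lower numbers stand for stronger inhibition and higher numbers for weaker inhibition. In this assay compound 1 reaches only the limit of the measurement, > 30000 nM, and not a number. Compound 2 `CC(C)Cn1cnc2c(N)ncnc21` in this assay likewise gives only a limit, > 30000 nM. Among the compounds with values here, both values stand at the limit of > 30000 nM in this assay, at which 2 of the 2 values shown sit, so nothing separates the two compounds and no measured step between them exists. Compound 3 `Nc1ncnc2ncn(CCO)c12` differs from compound 1 by hydroxy in place of hydrogen on a saturated chain carbon, two bonds along the chain from an aromatic nitrogen. Within the data shown here, with no measured step to lean on, the change from compound 1 to compound 3 is expected to amount to a step that the limit leaves unreadable from compound 1 to compound 3, nothing beyond the usual scatter. Compound 3 is therefore estimated at 40000 nM, within 15000 nM to 150000 nM, most likely again reported only as a limit.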

Compound 3, inhibition constant: > 30000 nM
Compound 3 gave a limit, no number (the forecaster's own chance of this, stated with the estimate: 85%); the middle value does not contradict the limit.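

Within the data shown here, compound 1 and compound 3 each give only a limit, so no step between them can be read: the limit of > 30000 nM in this assay, at which 3 of the 3 values shown sit. The compounds shown leave open whether hydroxy in place of hydrogen changes inhibition at all in this assay.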